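Compound 2 to compound 3: a thiophen-2-yl exchange

This account rests on a few compounds, and the source may have more. Where it says the series, first, only, none or still open, it means among the compounds named here.

Measured so far in a functional assay on MDA-MB-435 cells (Homo sapiens) for cytotoxicity, read by MTT assay, with a stated time of 72 h; on this read-out higher numbers stand for weaker inhibition and lower numbers for stronger inhibition:
- compound 1 `COc1cccc(CNC(=O)c2nc(Br)c3cccnc3c2N[C@H]2CC[C@H](N)CC2)c1` gives 7000 nM
- compound 2 `N[C@H]1CC[C@H](Nc2c(C(=O)NCc3cccc(C(F)(F)F)c3)nc(Br)c3cccnc23)CC1` gives 4200 nM

Among the compounds with values here, compound 2 stands at 4200 nM within the scatter of compound 1, the only other compound measured. Compound 3 `N[C@H]1CC[C@H](Nc2c(C(=O)NCc3cccs3)nc(Br)c3cccnc23)CC1` carries thiophen-2-yl in place of 3-(trifluoromethyl)phenyl on a saturated chain carbon bound to an amide-type nitrogen. Within the data shown here, only one measured step bears on this, and loosely: trifluoromethyl in place of methoxy on an aromatic carbon (a 1.7-fold lower number from compound 1 to compound 2 (0.22 log units; within the scatter)) stayed within the scatter. Among the measured compounds shown here, no measured step exchanges the whole aromatic group, so in this assay no step beyond the scatter is expected, and no direction can be argued. The estimate means an expected step of a 1.2-fold higher number from compound 2 to compound 3 (0.08 log units; within the scatter) and no more. Compound 3 is expected at 5000 nM (estimated range 2000 nM to 12000 nM).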

Compound 3, half-maximal inhibitory concentration: 4100 nM
Estimate against measurement, compound 3: 1.2-fold (0.09 log units) above; low and high end bracket the measured number.
By their numbers in this assay, from the lowest: compounds 3, 2 and 1 (each within the scatter of the next).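

In this assay, the change reaches beyond a substituent on the ring: the whole aromatic group on the saturated chain carbon bound to an amide-type nitrogen can be exchanged without a step beyond the scatter. Thiophen-2-yl in place of 3-(trifluoromethyl)phenyl gives (a 1.0-fold lower number from compound 2 to compound 3 (0.01 log units; within the scatter)), and thiophen-2-yl in place of 3-methoxyphenyl gives (a 1.7-fold lower number from compound 1 to compound 3 (0.23 log units; within the scatter)), so neither a six-membered aromatic ring of carbon only nor the trifluoromethyl or methoxy group is needed to keep the number in this range. Nothing available here explains this result.

As far as these compounds go, all three compounds keep an aromatic ring at this place, so it remains open how an amine, a carboxylic acid or a longer chain there would read in this assay. They also share the same core, which leaves the effect of changes elsewhere unknown.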